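This account rests on a few compounds, and the source may have more. Where it says the series, first, only, none or still open, it means among the compounds named here.

Compound 3 `NC(=O)CCc1c[nH]c2ccc(F)cc12` holds the lowest of the two numbers in an assay on isolated protein for inhibition of Myeloperoxidase (Homo sapiens), read by ELISA, with a stated time of 5 min (a higher number here means a weaker inhibitor, a lower number a stronger inhibitor), where compound 3 gives 34 nM. Compound 2 `N#CCCCc1c[nH]c2ccc(F)cc12` gives 72 nM, and a 2.1-fold lower number from compound 2 to compound 3 (0.33 log units; beyond the scatter). For compound 1 `CCCc1c[nH]c2ccc(F)cc12` this assay reports only a limit, > 100 nM. From that limit, an at least 2.9-fold lower number from compound 1 to compound 3 (0.46 log units; beyond the scatter), while an at least 1.3-fold lower number from compound 1 to compound 2 (0.14 log units; that floor lies within the scatter). Compound 4 `CCSCCc1c[nH]c2ccc(F)cc12` differs from compound 3 by ethylsulfanyl in place of carbamoyl on a saturated chain carbon, two bonds along the chain from an aromatic carbon. Both steps into compound 3 placed a carbamoyl where a methyl or a cyanomethyl had stood and lowered the number; removing the carbamoyl is expected to reverse part of that, so a modest rise is expected, a 2.4-fold higher number from compound 3 to compound 4 (0.37 log units; beyond the scatter). Compound 4 is therefore estimated at 80 nM, between 30 nM and 250 nM.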

Compound 4, half-maximal inhibitory concentration: > 100 nM
Compound 4: only a limit was reported (the forecaster's own chance of this, stated with the estimate: 25%); at least 1.2-fold (0.09 log units) between middle value and limit.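

In this assay compound 4 gives only a limit, > 100 nM. Ethylsulfanyl in place of carbamoyl at this saturated chain carbon gives an at least 2.9-fold higher number from compound 3 to compound 4 (0.46 log units; beyond the scatter), so at this position the carbamoyl cannot be swapped for ethylsulfanyl without a loss, whereas the comparison with the nitrile, an at least 1.3-fold higher number from compound 2 to compound 4 (0.14 log units; that floor lies within the scatter), separates nothing. The step from compound 1 to compound 4 cannot be read because both values are limits: the limit of > 100 nM in this assay, at which 2 of the 4 values shown sit.

Going by these compounds, it remains open whether a carboxylic acid, an amine or a longer chain ending in carbamoyl would match compound 3 at 34 nM.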